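This account rests on a few compounds, and the source may have more. Where it says the series, first, only, none or still open, it means among the compounds named here.

Compound 3 `COc1ccc(F)c([C@H]2CC[C@H](COc3cccc([C@H](C4CC4)[C@@H](F)C(=O)O)c3)CC2)c1` holds the second highest of the three numbers in a functional assay on HEK293 cells for agonist activity at Free fatty acid receptor 1 (Rattus norvegicus), read by FLIPR and calcium flux (a lower number here means that less compound is needed, a higher number that more compound is needed for the effect), where compound 3 gives 28 nM. Compound 1 `COc1ccc(F)c([C@H]2CC[C@H](COc3cccc([C@H](C4CC4)[C@@H](C)C(=O)O)c3)CC2)c1` gives 4.9 nM, and compound 2 `COc1ccc(F)c([C@H]2CC[C@H](COc3cccc([C@H](C4CC4)[C@H](F)C(=O)O)c3)CC2)c1` gives 163 nM. The step of a 5.7-fold higher number from compound 1 to compound 3 (0.76 log units; beyond the scatter) is modest, whereas the step of a 33-fold higher number from compound 1 to compound 2 (1.52 log units; beyond the scatter) is large. Compound 2 and compound 3 differ only in configuration as drawn (the fact that compounds 2 and 3 differ only in the configuration as drawn), and the step of a 5.8-fold lower number from compound 2 to compound 3 (0.77 log units; beyond the scatter) is modest.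

Compound 4 `COc1ccc(F)c([C@H]2CC[C@H](COc3cccc([C@H](C4CC4)[C@@](C)(F)C(=O)O)c3)CC2)c1` carries 1-carboxy-1-fluoroethyl in place of carboxy(fluoro)methyl on a saturated chain carbon bound to an aromatic carbon and a saturated ring carbon. This places the methyl of compound 1 and the fluorine of compound 3 on the same carbon. Among the compounds with values here, the steps that bear on it are a 5.7-fold higher number from compound 1 to compound 3 (0.76 log units; beyond the scatter), where fluorine took the place of methyl, and a 33-fold higher number from compound 1 to compound 2 (1.52 log units; beyond the scatter), which shows how much the drawn configuration at that carbon matters. Within the data shown here, no measured step shows what a carbon bearing both groups does, so the expected step is small and its direction uncertain. Compound 4 is expected to give 20 nM, within a range from 4 nM to 100 nM. The expected step is therefore a 1.4-fold lower number from compound 3 to compound 4 (0.15 log units; within the scatter).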

Compound 4, half-maximal effective concentration: 0.34 nM
Estimate against measurement, compound 4: 59-fold (1.77 log units) above; the whole stated range lies above it.
By their numbers in this assay, from the lowest: compound 4; then compound 1; then compound 3; then compound 2.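

Placing methyl and fluorine together on one carbon, as in the 1-carboxy-1-fluoroethyl group, gives a lower number in this assay than either group does alone: methyl in place of hydrogen brings an 82-fold lower number from compound 3 to compound 4 (1.92 log units; beyond the scatter) and a 480-fold lower number from compound 2 to compound 4 (2.68 log units; beyond the scatter), while fluoro in place of hydrogen brings a 14-fold lower number from compound 1 to compound 4 (1.16 log units; beyond the scatter). The earlier steps shown here did not point this way, since fluoro in place of methyl had raised the number, whereas adding fluoro while keeping the methyl lowers it. Nothing measured here gives a reason for this gain.

As far as these compounds go, only one configuration of the carbon bearing both groups appears, so the opposite configuration remains open. From the compounds shown here alone, whether an ethyl group in place of the methyl, or a hydroxyl group in place of the fluorine, would keep so low a number is also open.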